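The compounds below may be only part of what the source reports. "The series", "measured", "known", "first", "only" and "open" are said of these compounds alone.

Measured compounds:
Compound 1, `CCCCCCCCc1ccc(OCC(=O)Cn2ccc3ncccc32)cc1`; in an assay on microsomes from brain for inhibition of Fatty-acid amide hydrolase 1 (Rattus norvegicus), read by fluorescence and HPLC, with a stated time of 60 min (a higher number here means a weaker inhibitor, a lower number a stronger inhibitor), compound 1 gives > 10000 nM, which is a limit of the assay rather than a number.
Compound 2, `CCCCCCCCc1ccc(OCC(=O)Cn2nccn2)cc1`; in this assay compound 2 gives 100 nM.

Compound 2 therefore stands as the only numbered result in this assay, while compound 1 sits at the assay limit (the limit of > 10000 nM in this assay, at which 1 of the 2 values shown sits). Among the measured compounds shown here, the one measured step, an at least 100-fold lower number from compound 1 to compound 2 (2.00 log units; beyond the scatter), is large and beyond the scatter; it replaces the larger group of compound 1 with the triazole of compound 2 at the same position.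

Compound 3, `CCCCCCCCc1ccc(OCC(=O)Cn2ncnn2)cc1`, differs from compound 2 by 2H-tetrazol-2-yl in place of 2H-1,2,3-triazol-2-yl on a saturated chain carbon bound to a carbonyl carbon. For the measured compounds named here, the measured step bears on this position but compares groups of very different size, whereas here one small ring is exchanged for another of the same atom count; no measured step compares two such rings. The step from compound 2 to compound 3 is therefore expected to be small, a 1.5-fold higher number from compound 2 to compound 3 (0.18 log units; within the scatter), likely within the scatter. Compound 3 is estimated at 150 nM, with a range of 40 nM to 600 nM.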

Compound 3, half-maximal inhibitory concentration: 10 nM
Compound 3: middle estimate off by 15-fold (1.18 log units), on the high side; measured number below the stated range.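

In this assay, 2H-tetrazol-2-yl in place of 2H-1,2,3-triazol-2-yl gives a 10-fold lower number from compound 2 to compound 3 (1.00 log units; beyond the scatter), so this position, on a saturated chain carbon bound to a carbonyl carbon, also tells apart two five-membered aromatic rings with the same number of heavy atoms, not only groups of very different size. Measured against the larger group, the tetrazole gives an at least 1000-fold lower number from compound 1 to compound 3 (3.00 log units; beyond the scatter). That step is a bound rather than an exact size, and compound 1 gives a limit of the assay: the limit of > 10000 nM in this assay, at which 1 of the 3 values shown sits.

The compounds shown leave open whether other small rings at this position, such as an imidazole or a pyrazole, would give numbers nearer to compound 2 or compound 3. They also leave open whether the gain from the tetrazole would hold with a shorter chain on the shared core.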